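Ethyl on the Amide Nitrogen of Compound 3

A few compounds are considered here, and "the series" means these few. Any claim that something is new, unique, unknown or untested is made for them only; others in the source may bear on it.

All four compounds share the core of compound 1 `CCCc1c[nH]c2ccc(F)cc12` and differ only in the chain on it. In an assay on isolated protein (urine) for inhibition of Myeloperoxidase (Homo sapiens), with a stated time of 5 min (on this read-out higher numbers stand for weaker inhibition and lower numbers for stronger inhibition), compound 1 gives only a limit, > 100 nM; this is the limit of > 100 nM in this assay, at which 1 of the 3 values shown sits. Compound 2 `NC(=O)CCc1c[nH]c2ccc(F)cc12` gives 132 nM in this assay, and compound 3 `NC(=O)CCCc1c[nH]c2ccc(F)cc12` gives 18 nM, the lowest of the two numbers read, reached by a 7.3-fold lower number from compound 2 to compound 3 (0.87 log units; beyond the scatter) and by an at least 5.5-fold lower number from compound 1 to compound 3 (0.74 log units; beyond the scatter). Compound 4 `CCNC(=O)CCCc1c[nH]c2ccc(F)cc12` carries ethyl in place of hydrogen on an amide-type nitrogen. No measured step touches the amide nitrogen; the steps shown only add or extend the carbamoyl chain. For compound 4 in this assay a change of no more than the usual scatter, leaning weaker, is expected, a 1.7-fold higher number from compound 3 to compound 4 (0.22 log units; within the scatter). Compound 4 is therefore estimated at 30 nM, between 8 nM and 120 nM.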

Compound 4, half-maximal inhibitory concentration: 182 nM
Estimate against measurement, compound 4: 6.1-fold (0.78 log units) below; the whole stated range lies below it.
By their numbers in this assay, from the lowest: compound 3; then compounds 2 and 4 (each within the scatter of the next).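

The amide hydrogen of compound 3 does not tolerate replacement here: in this assay ethyl on the amide-type nitrogen gives a 10-fold higher number from compound 3 to compound 4 (1.00 log units; beyond the scatter). The gain from the longer chain is lost with this ethyl, leaving a 1.4-fold higher number from compound 2 to compound 4 (0.14 log units; within the scatter). The step from compound 1 to compound 4 cannot be read, since compound 1 gives only a limit: the limit of > 100 nM in this assay, at which 1 of the 4 values shown sits.

From the compounds shown here alone, what methyl on the amide nitrogen would give stays open. So does whether a carboxylic acid in place of the carbamoyl would hold the level of compound 3.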